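A Methoxy Addition Carried Over to a Second Core

The source may hold more compounds than are shown below. What is called first, only, known or untested is meant among the compounds shown, and "the series" means these compounds.

Of the compounds shown here, three have been measured in an assay on HeLa cells for displacement of a labelled ligand from 5-hydroxytryptamine receptor 6 (Homo sapiens), with a stated time of 2 h; on this read-out lower numbers stand for stronger inhibition and higher numbers for weaker inhibition. Compound 1 `O=S(=O)(c1cccc(F)c1)c1cn(C2CCCNC2)c2ccccc12` gives 6 nM in this assay. Compound 2 `COc1ccc2c(c1)c(S(=O)(=O)c1cccc(F)c1)cn2C1CCCNC1` differs from compound 1 in one place: methoxy in place of hydrogen on an aromatic carbon. In this assay compound 2 gives 10.7 nM, and the step is a 1.8-fold higher number from compound 1 to compound 2 (0.25 log units; within the scatter). Compound 3 `O=S(=O)(c1cccc(Cl)c1)c1cn(C2CCNC2)c2ccccc12` is built on a different core; the difference between the two cores is not broken down here. In this assay compound 3 gives 3.2 nM. Its value lies within the scatter of that of compound 1, while its gap to compound 2 is beyond the scatter.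

Compound 4 `COc1ccc2c(S(=O)(=O)c3cccc(Cl)c3)cn(C3CCNC3)c2c1` has not yet been measured. It differs from compound 3 in one place: methoxy in place of hydrogen on an aromatic carbon. This is the same change that takes compound 1 to compound 2, in the same kind of place on the ring. Within the data shown here, that earlier step is the only guide available, and it stayed within the scatter of repeated measurements. Compound 4 is therefore expected to stay close to compound 3, with an estimated step of a 1.8-fold higher number from compound 3 to compound 4 (0.26 log units; within the scatter), because a 1.8-fold higher number from compound 1 to compound 2 (0.25 log units; within the scatter) was small. In this assay compound 4 is expected to give about 5.8 nM, most likely between 2.5 nM and 14 nM.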

Compound 4, inhibition constant: 4.6 nM
Compound 4: the middle estimate sits 1.3-fold (0.10 log units) above what was measured, within the range that was stated.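

In this assay, putting methoxy in place of hydrogen on an aromatic carbon gives a 1.4-fold higher number from compound 3 to compound 4 (0.16 log units; within the scatter), a step too small to distinguish from repeat-to-repeat variation. Set beside the same change on the other core, the result looks much the same, and in these two cases the change carries across without a detectable difference: the same change on two cores in this assay, a 1.8-fold higher number (0.25 log units; within the scatter) from compound 1 to compound 2 and a 1.4-fold higher number (0.16 log units; within the scatter) from compound 3 to compound 4, 1.2-fold (0.09 log units) apart, within the scatter of two such steps. This shows only that methoxy was tolerated on both cores in this one binding read-out; neither step is large enough to count as a real effect, the agreement is between two small steps rather than two clear changes, and two pairs cannot establish a rule for other cores in the series.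

The compounds shown leave open whether a different group on that aromatic carbon, such as a carboxylic acid, an amine or a longer chain like butoxy, would also leave the number within the scatter or would move it clearly on either core. They also leave open whether methoxy would be tolerated as well on the other aromatic carbons of the ring, and whether any such result would carry from one core to the other.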